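A few compounds are considered here, and "the series" means these few. Any claim that something is new, unique, unknown or untested is made for them only; others in the source may bear on it.

Working notes on the series. Compound 1 `CC(C)C(NC(=O)NO)C(=O)NC1CCCCC1` in a functional assay on MOLT-4 cells (Homo sapiens) for inhibition (on this read-out lower numbers stand for stronger inhibition and higher numbers for weaker inhibition), reaches only a limit of the assay, > 100000 nM. Compound 2 `CCC(C)C1NC(=O)N(C2CCCCC2)C1=O` likewise stops at a limit in this assay, > 200000 nM. Going by the values given here, compound 3 `CCC(C)C(NC(=O)NO)C(=O)NC(c1ccccc1)c1ccccc1` is the one member with a number in this assay, 56000 nM. Compound 1 and compound 2 instead sit at the two limits (the limit of > 100000 nM in this assay, at which 1 of the 3 values shown sits, and (the limit of > 200000 nM in this assay, at which 1 of the 3 values shown sits)). Compound 4 `CCC(C)C(NC(=O)n1nnc2ccccc21)C(=O)NC(c1ccccc1)c1ccccc1` is not yet measured. It differs from compound 3 by a group of 9 heavy atoms (6 carbon, 3 nitrogen; one five-membered aromatic ring with 3 hetero atoms, one six-membered aromatic ring of carbon only) in place of a group of 2 heavy atoms (1 nitrogen, 1 oxygen; no ring), on a carbonyl carbon, so the hydroxyamino group that carries the hydrogen-bond donors is exchanged for an aromatic bicyclic group without donors. Among the compounds with values here, no measured pair shows such a change, so the step from compound 3 to compound 4 is expected to stay within scatter or to weaken inhibition, a 1.8-fold higher number from compound 3 to compound 4 (0.25 log units; within the scatter). Compound 4 is estimated in this assay at 100000 nM, between 20000 nM and 400000 nM.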

Compound 4, half-maximal inhibitory concentration: 79000 nM
For compound 4 the middle estimate is 1.3-fold (0.10 log units) above the measured one; measured number inside the range.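

In this assay, exchanging the hydroxyamino group on this carbonyl carbon for the group of 9 heavy atoms gives a 1.4-fold higher number from compound 3 to compound 4 (0.15 log units; within the scatter), so this position does not separate the two groups here. The entering group has no hydrogen-bond donors, so the hydroxyamino group is not needed for compound 4 to give a number rather than a limit. Nothing shown accounts for this step. From the compounds shown here alone, whether an amine or a methoxy group on this carbonyl carbon would move the number beyond the scatter stays open. Also open, going by these compounds, is how the group of 9 heavy atoms behaves on the core of compound 1.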